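Solubility of Two Measured Compounds and a Third Predicted

The compounds below may be only part of what the source reports. "The series", "measured", "known", "first", "only" and "open" are said of these compounds alone.

Compound 1: `COc1cc2cc(C(=O)CC3(O)CC[N+](C)(Cc4ccccc4)CC3)sc2cc1OC`; in a physicochemical assay for solubility (on this read-out higher numbers stand for higher solubility and lower numbers for lower solubility), compound 1 gives 1250 ug/mL
Compound 2: `COc1cc2cc(C(=O)CCc3cc[n+](C)cc3)sc2cc1OC`; in this assay compound 2 gives 3000 ug/mL

Of these two, compound 2 stands at the top of the measured numbers: its value is higher than that of compound 1, and the gap between them is wider than the usual scatter of repeated measurements. Within the data shown here, the two compounds share the same core but differ in several places at once, so no single structural step between them is known, and their two values can only be compared as they stand.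

The next compound, compound 3, has the structure `COCC[n+]1ccc(CCC(=O)c2cc3cc(OC)c(OC)cc3s2)cc1`. It differs from compound 2 in just one place: methoxymethyl in place of hydrogen on a saturated chain carbon bound to an aromatic nitrogen. The charged aromatic nitrogen and the rest of the molecule are kept unchanged. Among the measured compounds shown here, since no measured pair shows the effect of this kind of change, the expectation rests on the small size of the added group alone: a step that stays within the scatter, or at most a slight drop, is expected, which in numbers is the step of a 1.2-fold lower number from compound 2 to compound 3 (0.08 log units; within the scatter). Compound 3 is accordingly expected to give about 2500 ug/mL, with a plausible range from 1200 ug/mL to 5000 ug/mL.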

Compound 3, solubility: 33000 ug/mL
The estimate for compound 3 lay 13-fold (1.12 log units) below the measured number, outside the stated range (above it).
By their numbers in this assay, from the lowest: compound 1; then compound 2; then compound 3.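

Among these compounds, compound 2 and compound 3 differ in one place only, so this pair gives the first clean reading of a single change, which compound 1, differing from compound 2 in several places at once, could not give. In this assay, replacing methyl with 2-methoxyethyl on the charged aromatic nitrogen goes with an 11-fold higher number from compound 2 to compound 3 (1.04 log units; beyond the scatter), a large step for an addition of 3 heavy atoms with no ring and no net charge. This shows that the saturated chain carbon bound to the aromatic nitrogen is a sensitive place in this series, although nothing measured here explains why the number moves so far.

The compounds shown leave open whether the step belongs to the oxygen of the 2-methoxyethyl group or to the longer chain itself, a question that a plain propyl chain or a 2-hydroxyethyl group at the same place could help to settle. They also leave open how far the trend runs, since a single step says nothing about a longer ether chain or a chain ending in a carboxylic acid.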